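A few compounds are considered here, and "the series" means these few. Any claim that something is new, unique, unknown or untested is made for them only; others in the source may bear on it.

Working notes on the series.

Among the measured compounds shown here, compound 2 `Cc1nc2ccccc2c(=O)n1/N=C/c1ccc(Oc2ccc3ccccc3c2)cc1` has the highest number of the two so far in a physicochemical assay for lipophilicity, in phosphate buffer, measured as octanol-water partition; on this read-out lower numbers stand for lower lipophilicity and higher numbers for higher lipophilicity: compound 2 gives 5.22. Its nearest neighbour is compound 1 `Cc1nc2ccccc2c(=O)n1/N=C/c1ccc(Oc2ccc(Br)cc2)cc1`, which in this assay gives 4.64. For the measured compounds named here, the one measured step, a number 0.58 log units higher from compound 1 to compound 2 (beyond the scatter), is the only guide available here.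

Compound 3 `Cc1ccc(Oc2ccc(/C=N/n3c(C)nc4ccccc4c3=O)cc2)cc1` differs from compound 2 by 4-methylphenyl in place of naphthalen-2-yl on an oxygen on an aromatic ring. The measured step bears on it only in reverse: the change from 4-bromophenyl to naphthalen-2-yl raised this assay modestly, and the move from naphthalen-2-yl to 4-methylphenyl is expected to take the number back down by a step of comparable size, somewhat beyond the scatter, since 4-methylphenyl carries fewer heavy atoms than the group it replaces. For compound 3 the expected step is a number 0.87 log units lower from compound 2 to compound 3 (beyond the scatter). Compound 3 is therefore estimated at 4.35 in this assay, with a range from 3.95 to 4.75.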

Compound 3, partition coefficient: 4.32
Compound 3: middle estimate off by 0.03 log units, on the high side; low and high end bracket the measured number.
By their numbers in this assay, from the lowest: compound 3; then compound 1; then compound 2.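

Replacing naphthalen-2-yl with 4-methylphenyl at this position gives a number 0.90 log units lower from compound 2 to compound 3 (beyond the scatter) in this assay, so a single aromatic ring with a methyl group does not hold the number reached with the 2 six-membered aromatic rings. Methyl in place of bromo on an aromatic carbon gives a number 0.32 log units lower from compound 1 to compound 3 (beyond the scatter) in the same read-out, which separates the two single-ring groups as well and leaves compound 2 the highest of the three. Nothing measured here explains either step.

From the compounds shown here alone, all three compounds carry only a carbon aromatic ring on this oxygen, so the effect of an amine or a carboxylic acid on that ring remains open. Also open, going by these compounds, is whether a pyridine ring in this place, or a longer chain in place of methyl, would fit the same order.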